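The compounds below may be only part of what the source reports. "The series", "measured", "known", "first", "only" and "open" are said of these compounds alone.

Compound 1 `C/C(=C\C(=O)Nc1ccccc1OCCCC(=O)O)c1ccc2c(ccn2C)c1` gives 780 nM in an assay on Prostate gland for inhibition of steroid 5-alpha-reductase (Rattus norvegicus); on this read-out higher numbers stand for weaker inhibition and lower numbers for stronger inhibition; compound 2 `CCCCn1ccc2cc(/C(C)=C/C(=O)Nc3ccccc3OCCCC(=O)O)ccc21` gives 43 nM; compound 3 `CCCCCn1ccc2cc(/C(C)=C/C(=O)Nc3ccccc3OCCCC(=O)O)ccc21` gives 23 nM.

Compound 3 holds the lowest of the three numbers, though its gap to compound 2 lies within the scatter; only compound 1 stands clearly apart, with a 34-fold lower number from compound 1 to compound 3 (1.53 log units; beyond the scatter). Compound 4 `CCCCCCn1ccc2cc(/C(C)=C/C(=O)Nc3ccccc3OCCCC(=O)O)ccc21` differs from compound 3 by methyl in place of hydrogen on a saturated chain carbon, five bonds along the chain from an aromatic nitrogen. Within the data shown here, the steps that bear on this all run along the same chain: an 18-fold lower number from compound 1 to compound 2 (1.26 log units; beyond the scatter), a 34-fold lower number from compound 1 to compound 3 (1.53 log units; beyond the scatter) and, nearest in kind, a 1.9-fold lower number from compound 2 to compound 3 (0.27 log units; within the scatter). The large gains came with the first lengthening; going from butyl to pentyl moved the number only within the scatter. The step for compound 4 is therefore expected to be a 1.3-fold lower number from compound 3 to compound 4 (0.11 log units; within the scatter), nothing beyond the scatter. Compound 4 is estimated at 18 nM, between 8 nM and 45 nM.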

Compound 4, half-maximal inhibitory concentration: 77 nM
Beside the measured number, compound 4's estimate is 4.3-fold (0.63 log units) below it; measured number above the stated range.
By their numbers in this assay, from the lowest: compounds 3, 2 and 4 (each within the scatter of the next, the first and the last beyond it); then compound 1.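

Among these compounds, at this position the chain stops rewarding further growth: in this assay, methyl in place of hydrogen, five bonds along the chain from an aromatic nitrogen, brings the first upward step beyond the scatter (a 3.3-fold higher number from compound 3 to compound 4 (0.52 log units; beyond the scatter)). Most of the gain from the longer chains nevertheless survives, with the step from the shortest chain still large (a 10-fold lower number from compound 1 to compound 4 (1.01 log units; beyond the scatter)) and the step from butyl within the scatter (a 1.8-fold higher number from compound 2 to compound 4 (0.25 log units; within the scatter)). No evidence at hand accounts for this turn.

As far as these compounds go, whether a still longer chain such as heptyl continues the upward step remains open. So does the effect of a branched chain, or of a chain ending in a hydroxyl or an amine.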